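A few compounds are considered here, and "the series" means these few. Any claim that something is new, unique, unknown or untested is made for them only; others in the source may bear on it.

Values in a functional assay on DWD cells (Homo sapiens) for inhibition, read by sulforhodamine B assay; a lower number here means a stronger inhibitor of growth, a higher number a weaker inhibitor of growth:
- compound 1 `c1ccc(-c2ccc(-c3ccc(-c4nc5ccccc5[nH]4)cc3)cc2)cc1`: 100000 nM
- compound 2 `Cc1ccc2[nH]c(-c3ccc(-c4ccc(-c5ccc(N(C)C)cc5)cc4)cc3)nc2c1`: 3230 nM
- compound 3 `FC(F)(F)c1ccc(-c2ccc(-c3ccc(-c4nc5ccccc5[nH]4)cc3)cc2)cc1`: 100000 nM

In this assay, compound 3 stands level with compound 1, and the two share the highest number of the three. Among the measured compounds shown here, compound 2 is the only one with a lower number.

The next compound to be tested is compound 4 `COc1ccc(-c2ccc(-c3ccc(-c4nc5ccccc5[nH]4)cc3)cc2)cc1`, which has methoxy in place of trifluoromethyl on an aromatic carbon, para to a large group. The counted difference is methoxy in place of trifluoromethyl on an aromatic carbon and the rest of the molecule stays the same.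

For the measured compounds named here, one measured step bears directly on this carbon. The step of no change at the digits printed from compound 1 to compound 3 (within the scatter) is the swap of hydrogen for trifluoromethyl, so that swap shows no measurable effect on the number. Going by the values given here, compound 3 differs from compound 2 in more than one place, so compound 2 at 3230 nM gives no clean step for methoxy, though it does show that a compound of this general shape can reach a much lower number. The data do not include any methoxy compound. A modest move toward a lower number is therefore expected, and no change at all remains quite possible.

That expectation amounts to an estimated 2.5-fold lower number from compound 3 to compound 4 (0.40 log units; beyond the scatter) in this assay.

For compound 4 the estimated value is 40000 nM, with an expected range from 6000 nM to 100000 nM.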

Compound 4, concentration for 50% growth inhibition: 100000 nM
Estimate against measurement, compound 4: 2.5-fold (0.40 log units) below; the range from low to high includes it.
By their numbers in this assay, from the lowest: compound 2; then compounds 1, 3 and 4 (each within the scatter of the next).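

In this assay, methoxy in place of trifluoromethyl on this aromatic carbon reads (no change at the digits printed from compound 3 to compound 4 (within the scatter)), and methoxy in place of hydrogen reads (no change at the digits printed from compound 1 to compound 4 (within the scatter)). Earlier, only hydrogen and trifluoromethyl could be compared on this carbon, whereas now three different substituents give the same printed number, and one of them, methoxy, carries a hydrogen-bond acceptor that the other two lack. Among these three compounds, then, neither the choice of group at this position nor the presence of that acceptor goes with any measurable difference in growth inhibition, and no separate measurement is available to explain this flat result.

On these data alone, whether a different kind of group on the same carbon, such as a carboxylic acid or a nitrile, would shift the number remains open. As far as these compounds go, compound 2 (3230 nM) differs from these compounds in more than one place, so it also remains open which of its differences goes with its lower number.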